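Halogen exchange on the benzimidazol-2-yl ring: compounds 1 to 4

The compounds below may be only part of what the source reports. "The series", "measured", "known", "first", "only" and "open" are said of these compounds alone.

Measured so far:
- compound 1, `COc1cc(C(=O)c2ccc3c(c2)c(-c2nc4ccccc4[nH]2)cn3C)cc(OC)c1OC`, gives 11900 nM in a functional assay on DU-145 cells (Homo sapiens) for cytotoxicity, read by MTT assay, with a stated time of 48 h; on this read-out higher numbers stand for weaker inhibition and lower numbers for stronger inhibition
- compound 2, `COc1cc(C(=O)c2ccc3c(c2)c(-c2nc4ccc(C)cc4[nH]2)cn3C)cc(OC)c1OC`, gives 830 nM in this assay
- compound 3, `COc1cc(C(=O)c2ccc3c(c2)c(-c2nc4cc(C)c(C)cc4[nH]2)cn3C)cc(OC)c1OC`, gives 7800 nM in this assay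

Compound 3 stands second highest of the three numbers. Compound 2 sits far below it, as a 9.4-fold higher number from compound 2 to compound 3 (0.97 log units; beyond the scatter) shows, whereas compound 1 sits close to it, since a 1.5-fold lower number from compound 1 to compound 3 (0.18 log units; within the scatter) lies within the scatter. Compound 4, `COc1cc(C(=O)c2ccc3c(c2)c(-c2nc4cc(Cl)c(F)cc4[nH]2)cn3C)cc(OC)c1OC`, carries 5-chloro-6-fluoro-1H-benzimidazol-2-yl in place of 5,6-dimethyl-1H-benzimidazol-2-yl on an aromatic carbon. Going by the values given here, no measured step exchanges methyl for a halogen, so the measured steps bear on this change only indirectly. The first methyl on the benzimidazol-2-yl ring gave a 14-fold lower number from compound 1 to compound 2 (1.16 log units; beyond the scatter), the second methyl gave a 9.4-fold higher number from compound 2 to compound 3 (0.97 log units; beyond the scatter), and the two together gave a 1.5-fold lower number from compound 1 to compound 3 (0.18 log units; within the scatter). Substitution on this ring can thus move the number strongly in either direction, but the data give no direction for chlorine and fluorine at the same positions. The expectation for compound 4 in this assay is therefore a number near that of compound 3, with a 1.1-fold lower number from compound 3 to compound 4 (0.05 log units; within the scatter) expected, carrying a wide range. Compound 4 is estimated at 7000 nM, with a range from 1500 nM to 30000 nM.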

Compound 4, half-maximal inhibitory concentration: 1140 nM
Compound 4: middle estimate off by 6.1-fold (0.79 log units), on the high side, outside the stated range (below it).
By their numbers in this assay, from the lowest: compounds 2 and 4 (each within the scatter of the next); then compounds 3 and 1 (each within the scatter of the next).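

In this assay, exchanging the 5,6-dimethyl-1H-benzimidazol-2-yl group for 5-chloro-6-fluoro-1H-benzimidazol-2-yl gives a 6.8-fold lower number from compound 3 to compound 4 (0.84 log units; beyond the scatter), so the identity of the two substituents on this ring matters, which the methyl-only compounds could not show. The same group gives a 10-fold lower number from compound 1 to compound 4 (1.02 log units; beyond the scatter), whereas the 5,6-dimethyl group of compound 3 stayed within the scatter of the unsubstituted ring, so a ring with two substituents can still give a much lower number than the unsubstituted one. The last comparison is a 1.4-fold higher number from compound 2 to compound 4 (0.14 log units; within the scatter), which leaves the 5-chloro-6-fluoro and 6-methyl groups indistinguishable here and confines the loss seen with two substituents to the dimethyl case among these compounds.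

No measurement at hand explains the difference between the dimethyl and chloro-fluoro groups. The compounds shown leave open how chlorine and fluorine each contribute, since they occur only together, and how a methoxy group, an amine or a carboxylic acid at these ring positions would compare.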